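A few compounds are considered here, and "the series" means these few. Any claim that something is new, unique, unknown or untested is made for them only; others in the source may bear on it.

Measured so far:
compound 1, `CCCn1c(=O)n(CCC(=O)O)c(=O)c2[nH]cnc21`: > 200000 nM
compound 2, `CCCn1c(=O)n(CCN(C)C)c(=O)c2[nH]cnc21`: 4300 nM

Among the compounds with values here, in an assay on Cerebral cortex for binding affinity to adenosine receptor A1 (Cavia porcellus), read by radioligand binding (on this read-out lower numbers stand for stronger inhibition and higher numbers for weaker inhibition), compound 2 gives 4300 nM, the only actual number in this small set. For compound 1 the assay reports a limit, > 200000 nM, and not a number, as shown by the limit of > 200000 nM in this assay, at which 1 of the 2 values shown sits. Within the data shown here, the single measured step is an at least 46-fold lower number from compound 1 to compound 2 (1.66 log units; beyond the scatter), which means that the group on this chain carbon can shift the read-out a great deal.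

Compound 3, `CCCn1c(=O)n(CCOC)c(=O)c2[nH]cnc21`, differs from compound 2 in one place: methoxy in place of dimethylamino on a saturated chain carbon, two bonds along the chain from an aromatic nitrogen. Among the measured compounds shown here, only the step from compound 1 to compound 2 bears on this change, and it concerns the carboxy group rather than the methoxy group, so it offers rough guidance at best. For the measured compounds named here, no measured compound carries methoxy at this position. A change that stays within the scatter, or a modest shift toward lower numbers, is therefore expected, a 2.2-fold lower number from compound 2 to compound 3 (0.33 log units; beyond the scatter). The estimate for compound 3 is 2000 nM, with a range from 500 nM to 10000 nM.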

Compound 3, inhibition constant: 2500 nM
Compound 3: middle estimate off by 1.3-fold (0.10 log units), on the low side; low and high end bracket the measured number.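

In this assay the exchange of dimethylamino for methoxy on this saturated chain carbon is a 1.7-fold lower number from compound 2 to compound 3 (0.24 log units; within the scatter), so compound 2 and compound 3 cannot be told apart on this read-out, even though the nitrogen of the side chain has given way to an oxygen. The step from the carboxy group is again large, an at least 80-fold lower number from compound 1 to compound 3 (1.90 log units; beyond the scatter), which shows that the large difference seen earlier is not tied to dimethylamino: of the three groups shown at this place, only carboxy, in compound 1, stands apart from the others. The value of compound 1 is a limit and not a number, so both large steps give only a minimum size: the limit of > 200000 nM in this assay, at which 1 of the 3 values shown sits.

The compounds shown leave open whether a primary amine, a hydroxyl group or an amide at this place would read like methoxy and dimethylamino or like carboxy. They also leave open how a longer chain between the aromatic nitrogen and the end group, or a larger group than propyl on the other nitrogen of the shared core, would change the number in this assay.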